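The source may hold more compounds than are shown below. What is called first, only, known or untested is meant among the compounds shown, and "the series" means these compounds.

Series notes, two measured compounds and one pending. Compound 1 `COc1cccc(Cc2cnc(CCc3ccc(-c4ccccc4C(=O)O)cc3)[nH]2)c1` gives 4120 nM in an in vitro functional assay on cells for agonist activity at Bombesin receptor subtype-3 (Homo sapiens), read by luminescence and calcium flux; a higher number here means that more compound is needed for the effect, a lower number that less compound is needed. Within the data shown here, compound 2 `O=C(O)c1ccccc1-c1ccc(CCc2ncc(Cc3ccc(F)cc3)[nH]2)cc1` gives 1600 nM in this assay, the lowest of the two numbers so far; the only measured step, a 2.6-fold lower number from compound 1 to compound 2 (0.41 log units; beyond the scatter), separates the pair. Compound 3 `O=C(O)c1ccccc1-c1ccc(CCc2ncc(C3CCCCC3)[nH]2)cc1` carries the change cyclohexyl in place of 4-fluorobenzyl on an aromatic carbon on the shared core of compound 2. Among the measured compounds shown here, no measured step touches this position with a non-aromatic group: the step from compound 1 to compound 2 exchanges one six-membered aromatic ring for another and says nothing about removing the aromatic ring and the saturated chain carbon altogether. That step was modest, so a swing of similar size in either direction in this assay is plausible, with no basis in the data to prefer a direction. Compound 3 is therefore expected to give about 2500 nM in this assay, within 600 nM to 10000 nM, which amounts to an expected step of a 1.6-fold higher number from compound 2 to compound 3 (0.19 log units; within the scatter).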

Compound 3, half-maximal effective concentration: 375 nM
Compound 3: the middle estimate sits 6.7-fold (0.82 log units) above what was measured; the measured number lies below the stated range.
By their numbers in this assay, from the lowest: compound 3; then compound 2; then compound 1.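

In this assay, the position on the aromatic carbon of the five-membered ring accepts a non-aromatic ring: cyclohexyl in place of 4-fluorobenzyl gives a 4.3-fold lower number from compound 2 to compound 3 (0.63 log units; beyond the scatter), and cyclohexyl in place of 3-methoxybenzyl gives an 11-fold lower number from compound 1 to compound 3 (1.04 log units; beyond the scatter). The earlier step only exchanged one substituted benzyl group for another, whereas this change removes both the aromatic ring and the saturated chain carbon and gives the lowest number of the three compounds. Nothing available gives a reason for the direction or size of these steps.

The compounds shown leave open whether the lower number follows the non-aromatic ring or the loss of the saturated chain carbon, a question that cyclohexylmethyl at this position would separate. Also open, going by these compounds, is how the position responds to a smaller ring such as cyclopentyl or a ring bearing an amine such as piperidinyl.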